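Compound 2 loses its carbonyl group: what to expect

The source may report more compounds than this note shows. Statements on the series, on what has been measured and on what is new or still open speak of the compounds shown alone.

compound 1 `O=C(c1ccccc1)N1CCC(NS(=O)(=O)c2cc(S(=O)(=O)c3ccccc3)ccc2C(F)(F)F)CC1`: 12500 nM
compound 2 `O=C(c1ccc(Cl)nc1)N1CCC(NS(=O)(=O)c2cc(S(=O)(=O)c3ccccc3)ccc2C(F)(F)F)CC1`: 25000 nM
compound 3 `O=S(=O)(NC1CCN(S(=O)(=O)c2cccc(-c3nnn[nH]3)c2)CC1)c1cc(S(=O)(=O)c2ccccc2)ccc1C(F)(F)F`: 100000 nM

All three compounds were read in a physicochemical assay for solubility (on this read-out higher numbers stand for higher solubility and lower numbers for lower solubility), and share one core. Compound 2 gives 25000 nM and lies within the scatter of compound 1, while compound 3 stands beyond the scatter on the higher side of compound 2.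

The compound still to be measured is compound 4 `CC(C)(O)CCN1CCC(NS(=O)(=O)c2cc(S(=O)(=O)c3ccccc3)ccc2C(F)(F)F)CC1` in which 3-hydroxy-3-methylbutyl takes the place of (6-chloropyridin-3-yl)carbonyl on an amine nitrogen in a ring (3-hydroxy-3-methylbutyl in place of (6-chloropyridin-3-yl)carbonyl on an amine nitrogen in a ring). For the measured compounds named here, one measured step touches this part of the structure: a 2.0-fold higher number from compound 1 to compound 2 (0.30 log units; within the scatter) for a change on the carbonyl carbon. Going by the values given here, that step stayed within the scatter, but no measured pair shows the carbonyl being removed, so it offers only weak guidance. Compound 3 has a different group at that place and gives 100000 nM so higher numbers do occur in this small set. A modest upward step is therefore expected in this assay with wide uncertainty. The expected step is a 2.0-fold higher number from compound 2 to compound 4 (0.30 log units; within the scatter) in this read-out. Compound 4 is estimated at 50000 nM with an expected range of 20000 nM to 100000 nM in this read-out.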

Compound 4, solubility: 50000 nM
Estimate against measurement, compound 4: no gap at the digits printed; measured number inside the range.
By their numbers in this assay, from the lowest: compounds 1, 2, 4 and 3 (each within the scatter of the next, the first and the last beyond it).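

In this assay, 3-hydroxy-3-methylbutyl on the amine nitrogen in a ring gives a 2.0-fold higher number from compound 2 to compound 4 (0.30 log units; within the scatter) against (6-chloropyridin-3-yl)carbonyl, and a 4.0-fold higher number from compound 1 to compound 4 (0.60 log units; beyond the scatter) against benzoyl. For the compounds shown here, these are the first steps at this position that remove the carbonyl and the aromatic ring together, and the one from benzoyl is the first step here to pass beyond the scatter, so a chain with no ring on this nitrogen keeps the number at the upper end of the set, with only compound 3 printing a higher figure, while the step from the chloropyridine amide alone stays within the scatter and does not separate the two compounds. Nothing measured here gives a reason for either step.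

The compounds shown leave open which part of the change carries the step from benzoyl, the loss of the carbonyl, the loss of the aromatic ring or the hydroxyl of the new chain, and a plain 3-methylbutyl chain or a benzyl group on the same nitrogen would begin to tell these apart. Also open, as far as these compounds go, is how a chain ending in an amine or a carboxylic acid would read at this position in this assay.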